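A few compounds are considered here, and "the series" means these few. Any claim that something is new, unique, unknown or untested is made for them only; others in the source may bear on it.

Working notes on the series. Compound 1 `CC1(C)CCC(C)(C)c2cc(C(=O)/C=C/c3c[nH]c4ccccc34)ccc21` gives 20 nM in a functional assay on HCT-116 cells (Homo sapiens) for cytotoxicity, read by sulforhodamine B assay, with a stated time of 3 days; a higher number here means a weaker inhibitor, a lower number a stronger inhibitor. Compound 2 `COc1ccc2[nH]cc(/C=C/C(=O)c3ccc4c(c3)C(C)(C)CCC4(C)C)c2c1` gives 13900 nM, and compound 3 `CC1(C)CCC(C)(C)c2cc(C(=O)/C=C/c3c[nH]c4ccc(Cl)cc34)ccc21` gives 10700 nM. The two steps from the unsubstituted indole are large: a 700-fold higher number from compound 1 to compound 2 (2.84 log units; beyond the scatter) and a 540-fold higher number from compound 1 to compound 3 (2.73 log units; beyond the scatter). Between the two substituted analogues the difference is small: a 1.3-fold lower number from compound 2 to compound 3 (0.11 log units; within the scatter). Compound 3 therefore stands second highest of the three numbers, close to compound 2 and far from compound 1.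

Compound 4 `CC1(C)CCC(C)(C)c2cc(C(=O)/C=C/c3c[nH]c4ccc(Br)cc34)ccc21` differs from compound 3 by bromo in place of chloro on an aromatic carbon. The step that bears on this is the one from methoxy to chloro on that aromatic carbon, a 1.3-fold lower number from compound 2 to compound 3 (0.11 log units; within the scatter), which stayed within the scatter; both groups there cost a large amount against compound 1. On that basis no step beyond the scatter is expected in this assay from compound 3 to compound 4, and the estimated step is a 1.1-fold lower number from compound 3 to compound 4 (0.03 log units; within the scatter). Compound 4 is estimated at 10000 nM, with a range of 3000 nM to 35000 nM.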

Compound 4, half-maximal inhibitory concentration: 10800 nM
Beside the measured number, compound 4's estimate is 1.1-fold (0.03 log units) below it, and the stated range covers the measured number.
By their numbers in this assay, from the lowest: compound 1; then compounds 3, 4 and 2 (each within the scatter of the next).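

In this assay, bromo and chloro at this aromatic carbon cannot be told apart (a 1.0-fold higher number from compound 3 to compound 4 (0.00 log units; within the scatter)), and bromo and methoxy also stay within the scatter (a 1.3-fold lower number from compound 2 to compound 4 (0.11 log units; within the scatter)), so all three substituted compounds now form one group. A third group in place of hydrogen brings the same large penalty (a 540-fold higher number from compound 1 to compound 4 (2.73 log units; beyond the scatter)), so among compounds 1 to 4 the loss goes with having chloro, bromo or methoxy there at all and does not differ among these three groups. No measurement shown here gives a cause for this flat penalty.

From the compounds shown here alone, whether fluoro, hydroxyl or an amine at this aromatic carbon would share the penalty or return toward compound 1 remains open. Also open, going by these compounds, is whether these groups cost as much on the other aromatic carbons of that ring.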